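A few compounds are considered here, and "the series" means these few. Any claim that something is new, unique, unknown or untested is made for them only; others in the source may bear on it.

Compound 1 `Cc1ccc(/C=C2\SC(=S)N(NS(=O)(=O)c3ccccc3)C2=O)cc1`: in a functional assay on ECV-304 cells (Homo sapiens) for cytotoxicity (on this read-out higher numbers stand for weaker inhibition and lower numbers for stronger inhibition), compound 1 gives only a limit, > 50000 nM.
Compound 2 `Cc1cccc(/C=C2\SC(=S)N(NS(=O)(=O)c3ccccc3)C2=O)c1`: in this assay compound 2 gives only a limit, > 50000 nM.

Compound 2 therefore stands at the limit of > 50000 nM in this assay, at which 2 of the 2 values shown sit, with no number of its own. Compound 3 `O=C1/C(=C/c2cc(F)ccc2F)SC(=S)N1NS(=O)(=O)c1ccccc1` differs from compound 2 by 2,5-difluorophenyl in place of 3-methylphenyl on a double-bonded chain carbon bound to a double-bonded ring carbon. Among the measured compounds shown here, the only measured step that bears on this change is a step that the two limits leave unreadable from compound 1 to compound 2, and two limits leave its size unreadable, so no step beyond the scatter in this assay can be expected; the step that the limit leaves unreadable from compound 2 to compound 3 is an estimate only. Compound 3 is expected to give about 60000 nM, within 20000 nM to 200000 nM, most probably again as a limit.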

Compound 3, half-maximal inhibitory concentration: > 50000 nM
Compound 3: a limit, no number; the forecaster's own chance of this, stated with the estimate: 75%; the middle value is on the limit's open side.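

Compound 3 also gives only a limit, > 50000 nM, so no step can be read among compound 1, compound 2 and compound 3. The compounds shown leave open whether these three groups differ at all in this assay.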